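The compounds below may be only part of what the source reports. "The series", "measured", "known", "first", "only" and "open" are said of these compounds alone.

Measured so far in a functional assay on MDA-MB-231 cells (Homo sapiens) for inhibition, read by sulforhodamine B assay, tested at 10 uM; a higher number here means more inhibition at the concentration tested (going by the name of the read-out), a lower number less inhibition:

compound 1 `Cc1ccc(S(=O)(=O)N2N=C(c3ccc(-n4cncn4)cc3)CC2c2ccc(N(C)C)cc2)cc1` gives 20.7%
compound 2 `CN(C)c1ccc(C2CC(c3ccc(-n4cncn4)cc3)=NN2S(=O)(=O)c2ccc(Br)cc2)cc1` gives 10.4%

Among the measured compounds shown here, compound 2 stands lowest of the two numbers; the only measured step, a number 10.3 percentage points lower from compound 1 to compound 2 (beyond the scatter), is modest though beyond the scatter. Compound 3 `CN(C)c1ccc(C2CC(c3ccc(-n4cncn4)cc3)=NN2S(=O)(=O)c2ccc(C(F)(F)F)cc2)cc1` differs from compound 2 by trifluoromethyl in place of bromo on an aromatic carbon. For the measured compounds named here, no measured step exchanges bromo for trifluoromethyl, so the step from compound 1 to compound 2 at the same position is the only guide, and it lowered inhibition only modestly. The step of a number 1.6 percentage points higher from compound 2 to compound 3 (within the scatter) is therefore expected to lie within the scatter, with no clear direction. Compound 3 is estimated at 12%, in the range 0% to 28%.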

Compound 3, a percentage reported as inhibition, at one concentration (the size of the read-out at that concentration, not a potency): 15.3%
For compound 3 the middle estimate is 3.3 percentage points below the measured one; the measured number falls inside the stated range.
By their numbers in this assay, from the lowest: compounds 2, 3 and 1 (each within the scatter of the next, the first and the last beyond it).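

In this assay, trifluoromethyl in place of bromo gives a number 4.9 percentage points higher from compound 2 to compound 3 (within the scatter), and trifluoromethyl in place of methyl gives a number 5.4 percentage points lower from compound 1 to compound 3 (within the scatter). Compound 3 therefore cannot be ordered against either compound 1 or compound 2 at this position, and only a number 10.3 percentage points lower from compound 1 to compound 2 (beyond the scatter) separates two of the three groups. Nothing available accounts for these differences.

As far as these compounds go, whether an amine, a methoxy group or a carboxylic acid at the same position would give a number clearly apart from these three remains open. From the compounds shown here alone, the effect of the same exchanges on a different core also remains open.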